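Fluoro for Methyl on the Anilino Group: Expected Effect

The source may report more compounds than this note shows. Statements on the series, on what has been measured and on what is new or still open speak of the compounds shown alone.

Compound 1 `CC(C)OC1=C(C(=O)c2ccccc2)C(c2ccc(Br)cc2)N(CCCn2ccnc2)C1=O` gives 18900 nM in a functional assay on NCI-H1299 cells (Homo sapiens) for antiproliferative activity, read by MTT assay, with a stated time of 72 h; a lower number here means a stronger inhibitor, a higher number a weaker inhibitor.
Compound 2 `Cc1ccc(NC2=C(C(=O)c3ccccc3)C(c3ccc(Br)cc3)N(CCCn3ccnc3)C2=O)cc1` gives 25800 nM in this assay.

Compound 2 stands level with compound 1: the step of a 1.4-fold higher number from compound 1 to compound 2 (0.14 log units; within the scatter) is within the scatter. Compound 3 `O=C(C1=C(Nc2ccc(F)cc2)C(=O)N(CCCn2ccnc2)C1c1ccc(Br)cc1)c1ccccc1` differs from compound 2 by fluoro in place of methyl on an aromatic carbon. For the measured compounds named here, no measured step bears on this change; the only measured step, a 1.4-fold higher number from compound 1 to compound 2 (0.14 log units; within the scatter), concerns a different position and is itself within the scatter. The expectation for compound 3 is therefore a step of no size beyond the scatter in this assay, namely a 1.0-fold lower number from compound 2 to compound 3 (0.01 log units; within the scatter). Compound 3 is estimated at 25000 nM, with a range from 9000 nM to 70000 nM.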

Compound 3, half-maximal inhibitory concentration: 25400 nM
Compound 3: middle estimate off by 1.0-fold (0.01 log units), on the low side; the range from low to high includes it.
By their numbers in this assay, from the lowest: compounds 1, 3 and 2 (each within the scatter of the next).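

In this assay, the swap from the (4-methylphenyl)amino to the (4-fluorophenyl)amino group gives a 1.0-fold lower number from compound 2 to compound 3 (0.01 log units; within the scatter), so methyl and fluoro read alike at this ring position. Fluoro also leaves the comparison with the ether unchanged, with a 1.3-fold higher number from compound 1 to compound 3 (0.13 log units; within the scatter), and both aryl amino compounds stay level with the isopropoxy compound. No measured evidence explains this sameness.

On these data alone, whether a larger group on that ring, such as trifluoromethyl or methoxy, would move the number remains open. So does whether a carboxylic acid or a simple amine there would do so.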